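The source may report more compounds than this note shows. Statements on the series, on what has been measured and on what is new or still open speak of the compounds shown alone.

Compound 1 `COc1cc2[nH]c(C)c(-c3ccc(Oc4ccc(F)cc4)cc3)c(=O)c2cc1Cl` in an ADME assay on HepG2 cells (Homo sapiens) for cytotoxicity, read by resazurin assay, with a stated time of 24 h (on this read-out higher numbers stand for weaker inhibition and lower numbers for stronger inhibition), gives > 10000 nM, which is a limit of the assay rather than a number.
Compound 2 `COc1cc2[nH]c(C)c(-c3ccc(Oc4ccc(Cl)cc4)cc3)c(=O)c2cc1Cl` gives > 10000 nM, likewise a limit.
Compound 3 `COc1cc2[nH]c(C)c(-c3ccc(Oc4ccc(OC(F)(F)F)cc4)cc3)c(=O)c2cc1Cl` gives > 10000 nM, also a limit.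

From compound 2 to compound 1 the change is fluoro in place of chloro on an aromatic carbon; the step that the two limits leave unreadable from compound 2 to compound 1 cannot be read, because of the limit of > 10000 nM in this assay, at which 3 of the 3 values shown sit. The same kind of change is made from compound 3 to compound 4 `COc1cc2[nH]c(C)c(-c3ccc(Oc4ccc(OC(F)(F)F)cc4)cc3)c(=O)c2cc1F`, not yet measured: fluoro in place of chloro on an aromatic carbon. The place differs, though: in compound 4 it is on a ring that is part of a fused or bridged system, ortho to a methoxy group and meta and para to a fused ring, whereas in compound 1 it is para to a large group. The cores of compound 2 and compound 3 differ by trifluoromethoxy in place of chloro on an aromatic carbon.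

The step from compound 3 to compound 4 in this assay is expected to be a step that the limit leaves unreadable from compound 3 to compound 4, resting on (the limit of > 10000 nM in this assay, at which 3 of the 3 values shown sit). Compound 4 is estimated at 20000 nM, between 8000 nM and 60000 nM, most likely again reported only as a limit.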

Compound 4, half-maximal inhibitory concentration: > 10000 nM
Compound 4 gave a limit, no number (the forecaster's own chance of this, stated with the estimate: 85%); the middle value is on the limit's open side.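

No size can be read for the change from compound 3 to compound 4 in this assay, because both values are limits: the limit of > 10000 nM in this assay, at which 4 of the 4 values shown sit.

The compounds shown leave open how far past that limit each one lies, and whether fluoro in place of chloro changes the read-out at all.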